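Adding the same hydroxymethyl on a lower-starting core

The compounds below may be only part of what the source reports. "The series", "measured", "known", "first", "only" and "open" are said of these compounds alone.

Compound 1 `COc1ccccc1C1C(C(=O)C(C)(C)C)=C(O)C(=O)N1c1ccc(-c2ccon2)cc1` and compound 2 `CC(C)(C)C(=O)C1=C(O)C(=O)N(c2ccc(-c3ccon3)cc2)C1c1ccccc1OCCO` differ in one place: hydroxymethyl in place of hydrogen on a saturated chain carbon bound to an oxygen on an aromatic ring. In an ADME assay on the whole organism (Rattus norvegicus) for pharmacokinetics, at a dose of 1 mg/kg by the oral route (on this read-out higher numbers stand for higher oral bioavailability and lower numbers for lower oral bioavailability), compound 1 gives 77.9%, while compound 2 gives 49.9%, so this change produced a number 28 percentage points lower from compound 1 to compound 2 (beyond the scatter). Compound 3 `COc1ccccc1C1C(C(=O)C(C)C)=C(O)C(=O)N1c1ccc(-c2ccsc2)cc1` differs from compound 1 in more than one place, and the difference between the two cores is not broken down here; in this assay compound 3 gives 20%. Compound 4 `CC(C)C(=O)C1=C(O)C(=O)N(c2ccc(-c3ccsc3)cc2)C1c1ccccc1OCCO` is not yet measured and carries the same change as before: hydroxymethyl in place of hydrogen on a saturated chain carbon bound to an oxygen on an aromatic ring. Because the earlier step of a number 28 percentage points lower from compound 1 to compound 2 (beyond the scatter) lowered the number, a fall is expected again, and the step expected from compound 3 to compound 4 is a number 10 percentage points lower from compound 3 to compound 4 (within the scatter), held smaller by the little room left, since compound 3 gives 20%. Compound 4 is therefore estimated at 10%, probably between 2% and 25%.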

Compound 4, oral bioavailability: 40.8%
Estimate against measurement, compound 4: 30.8 percentage points below, and the stated range ends below it.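

In this assay, the hydroxymethyl change gives a number 20.8 percentage points higher from compound 3 to compound 4 (beyond the scatter). The size and even the direction of this step therefore depend on the core that carries it, so the result on one core does not predict the result on the other: the same change on two cores in this assay, a number 28 percentage points lower (beyond the scatter) from compound 1 to compound 2 and a number 20.8 percentage points higher (beyond the scatter) from compound 3 to compound 4, 48.8 percentage points apart, beyond the scatter of two such steps

These two pairs do not show which of the several differences between the cores is responsible, nor why the steps point in opposite directions. The compounds shown leave open how the change behaves on other cores and whether the hydroxyl itself matters. A 2-aminoethoxy group, or a longer chain such as 3-hydroxypropoxy, in the same place on both cores would address the second question.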